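Swapping the amide aryl group on a thiazolidinedione-bearing naphthalene scaffold

This account rests on a few compounds, and the source may have more. Where it says the series, first, only, none or still open, it means among the compounds named here.

Of the compounds shown here, three sharing one core have been measured in an assay on isolated protein for inhibition of histone deacetylase 4 (Homo sapiens), with a stated time of 1 h; a higher number here means a weaker inhibitor, a lower number a stronger inhibitor. Compound 1 `O=C(COc1ccc2cc(/C=C3/SC(=O)NC3=O)ccc2c1)Nc1ccc(Br)cc1` gives 2900 nM, compound 2 `Cc1cccc(NC(=O)COc2ccc3cc(/C=C4/SC(=O)NC4=O)ccc3c2)n1` gives 1100 nM, and compound 3 `CCOc1ccc2nc(NC(=O)COc3ccc4cc(/C=C5/SC(=O)NC5=O)ccc4c3)sc2c1` gives 3600 nM. Among these three, compound 2 shows the lowest number: its nearest neighbour is compound 1, and compound 3 stands furthest from it, both differences lying beyond the scatter. Within the data shown here, the one single-point step measured so far, a 2.6-fold lower number from compound 1 to compound 2 (0.42 log units; beyond the scatter), shows that the choice of group on the amide-type nitrogen moves the read-out by a modest but real amount.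

Compound 4 `Cc1cccc2sc(NC(=O)COc3ccc4cc(/C=C5/SC(=O)NC5=O)ccc4c3)nc12` is the next compound to be measured. It differs from compound 2 in one place: 4-methyl-1,3-benzothiazol-2-yl in place of 6-methylpyridin-2-yl on an amide-type nitrogen. Among the measured compounds shown here, no measured step covers exactly this exchange. The closest guide is compound 3, whose amide-type nitrogen also carries a benzothiazol-2-yl group and whose value of 3600 nM sits well above that of compound 2. On that basis compound 4 is expected to give a higher number than compound 2, with an estimated step of a 2.3-fold higher number from compound 2 to compound 4 (0.36 log units; beyond the scatter). The estimate for compound 4 in this assay is 2500 nM, with a likely range from 1000 nM to 6000 nM.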

Compound 4, half-maximal inhibitory concentration: 1200 nM
The estimate for compound 4 lay 2.1-fold (0.32 log units) above the measured number, within the range that was stated.
By their numbers in this assay, from the lowest: compounds 2 and 4 (each within the scatter of the next); then compounds 1 and 3 (each within the scatter of the next).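

The exchange of 6-methylpyridin-2-yl for 4-methyl-1,3-benzothiazol-2-yl on the amide-type nitrogen gives a 1.1-fold higher number from compound 2 to compound 4 (0.04 log units; within the scatter) in this assay, so these two groups, which differ in ring count and size, cannot be told apart here. Against 4-bromophenyl, the same benzothiazole group gives a 2.4-fold lower number from compound 1 to compound 4 (0.38 log units; beyond the scatter), making it the second group after 6-methylpyridin-2-yl to stand beyond the scatter from that group, yet a benzothiazol-2-yl group alone does not decide the number: compound 3, which also carries one, gives 3600 nM, while compound 4 gives 1200 nM. No supporting data offer an account of these values.

The compounds shown leave open what the methyl group of compound 4 contributes, a question that a plain 1,3-benzothiazol-2-yl group on the amide-type nitrogen would help to answer. They also leave open how this assay would respond to a carboxylic acid or an amine on the ring at this place, or to a longer chain between the amide-type nitrogen and the ring.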